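Chloro to Nitro: the Same Swap on Two Cores

The compounds below may be only part of what the source reports. "The series", "measured", "known", "first", "only" and "open" are said of these compounds alone.

Compound 2 `O=C1NC(=O)/C(=C/c2ccc(OCN3C(=O)c4ccccc4C3=O)c(Cl)c2)S1` and compound 1 `O=C1NC(=O)/C(=C/c2ccc(OCN3C(=O)c4ccccc4C3=O)c([N+](=O)[O-])c2)S1` share one core and differ in a single place: nitro in place of chloro on an aromatic carbon. In an assay on isolated protein for inhibition of Alpha glucosidase (Homo sapiens), read by spectrophotometry, with stated times of 15 min and 30 min (a lower number here means a stronger inhibitor, a higher number a weaker inhibitor), compound 2 gives 21000 nM and compound 1 gives 22500 nM, a step of a 1.1-fold higher number from compound 2 to compound 1 (0.03 log units; within the scatter). Compound 3 `O=C1NC(=S)S/C1=C\c1cc(Cl)ccc1OCN1C(=O)c2ccccc2C1=O` is built on another core; the difference between the two cores is not broken down here. In this assay compound 3 gives 34800 nM. Compound 4 `O=C1NC(=S)S/C1=C\c1cc([N+](=O)[O-])ccc1OCN1C(=O)c2ccccc2C1=O`, not yet measured, arises from compound 3 by the same kind of change: nitro in place of chloro on an aromatic carbon. The place is not the same word for word: in compound 1 the nitro is ortho to a large group, in compound 4 it is para to a large group. Resting on a 1.1-fold higher number from compound 2 to compound 1 (0.03 log units; within the scatter), the expected step is a 1.1-fold higher number from compound 3 to compound 4 (0.04 log units; within the scatter). Compound 4 is therefore estimated at 38000 nM, likely between 18000 nM and 80000 nM.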

Compound 4, half-maximal inhibitory concentration: 35800 nM
For compound 4 the middle estimate is 1.1-fold (0.03 log units) above the measured one; the measured number falls inside the stated range.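

In this assay, the new step is a 1.0-fold higher number from compound 3 to compound 4 (0.01 log units; within the scatter), so on this core too, nitro in place of chloro leaves the number within the scatter. For the compounds shown here, the two cores agree on this swap: the same change on two cores in this assay, a 1.1-fold higher number (0.03 log units; within the scatter) from compound 2 to compound 1 and a 1.0-fold higher number (0.01 log units; within the scatter) from compound 3 to compound 4, 1.0-fold (0.02 log units) apart, within the scatter of two such steps This shows only that the swap gave no readable change on either core, even though the nitro sits in a different place on each; it does not show that a swap with a real effect would carry across, since two flat steps are a weak test of transfer.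

The compounds shown leave open whether an amine or a carboxylic acid in place of the chloro would shift the number on either core.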